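Dichlorophenyl for difluorophenyl: one swap, two pairs

This account rests on a few compounds, and the source may have more. Where it says the series, first, only, none or still open, it means among the compounds named here.

Measured compounds:
Compound 1 `CN(C(=O)NC(=O)c1ccc(F)c(F)c1)c1nc(C(F)(F)F)c(C(=O)N/N=C/c2ccccc2C(F)(F)F)s1` gives 6.96 ug/mL in a functional assay on A549 cells (Homo sapiens) for inhibition, read by MTT assay, with a stated time of 72 h; on this read-out lower numbers stand for stronger inhibition and higher numbers for weaker inhibition.
Compound 2 `CN(C(=O)NC(=O)c1ccc(F)c(F)c1)c1nc(C(F)(F)F)c(C(=O)N/N=C/c2cc(C(F)(F)F)cc(C(F)(F)F)c2)s1` gives 5.47 ug/mL in this assay.
Compound 3 `CN(C(=O)NC(=O)c1ccc(Cl)cc1Cl)c1nc(C(F)(F)F)c(C(=O)N/N=C/c2cc(C(F)(F)F)cc(C(F)(F)F)c2)s1` gives > 100 ug/mL in this assay, and this value is a limit of the assay rather than a number.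

Compound 1 and compound 2 differ in more than one place; the difference between the two cores is not broken down here. Their two values sit within the scatter of each other, so no order between them is claimed.

The step from compound 2 to compound 3 is 2,4-dichlorophenyl in place of 3,4-difluorophenyl on a carbonyl carbon. It produces an at least 18-fold higher number from compound 2 to compound 3 (1.26 log units; beyond the scatter). The measured value of compound 3 sits at the limit of > 100 ug/mL in this assay, at which 1 of the 3 values shown sits, so the true size of that step is only bounded from below.

Compound 4 `CN(C(=O)NC(=O)c1ccc(Cl)cc1Cl)c1nc(C(F)(F)F)c(C(=O)N/N=C/c2ccccc2C(F)(F)F)s1` is not yet measured. Within the data shown here, it is related to compound 1 by 2,4-dichlorophenyl in place of 3,4-difluorophenyl on a carbonyl carbon, the same change, at the same place, as the one from compound 2 to compound 3. Among the measured compounds shown here, since compound 1 and compound 2 stand close together, and since the one measured instance of this change gave an at least 18-fold higher number from compound 2 to compound 3 (1.26 log units; beyond the scatter), a step of similar size is expected from compound 1 to compound 4, that is a 13-fold higher number from compound 1 to compound 4 (1.11 log units; beyond the scatter). Compound 4 is therefore estimated to reach 90 ug/mL in this assay, with a range of 25 ug/mL to 300 ug/mL, and it is expected that the assay may again report only a limit.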

Compound 4, half-maximal inhibitory concentration: 15.3 ug/mL
Compound 4: middle estimate off by 5.9-fold (0.77 log units), on the high side, and the stated range ends above it.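

In this assay, 2,4-dichlorophenyl in place of 3,4-difluorophenyl on the carbonyl carbon gives a 2.2-fold higher number from compound 1 to compound 4 (0.34 log units; beyond the scatter), so the direction of the earlier step recurs on this second core, but its size does not carry over: the same change on two cores in this assay, an at least 18-fold higher number (1.26 log units; beyond the scatter) from compound 2 to compound 3 and a 2.2-fold higher number (0.34 log units; beyond the scatter) from compound 1 to compound 4, at least 8.3-fold (0.91 log units) apart, beyond the scatter of two such steps

The value of compound 3, > 100 ug/mL, is a limit of the assay and not a number, so the larger of the two steps is bounded on one side only.

For these two pairs, the size of the change depends on the core that carries it, whereas the pairs do not show which part of the difference between the two cores is responsible, or how large the step would be on a third core.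

Still open, from the compounds shown here alone, is how the read-out responds when the aromatic group on the carbonyl carbon is replaced by an unsubstituted phenyl, a phenyl carrying a single chlorine, or a saturated chain. Going by these compounds, it is also open whether a carboxylic acid or a nitrile on the benzylidene ring would leave the difference between the two pairs intact.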